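Chloropyridyl Replacing Furan on a Thiazole Acetic Acid Series

The compounds below may be only part of what the source reports. "The series", "measured", "known", "first", "only" and "open" are said of these compounds alone.

Compound 1 `NS(=O)(=O)c1ccc(-c2nc(C(c3ccc(F)cc3)c3ccc(F)cc3)sc2CC(=O)O)cc1` reaches only the assay limit, > 100000 nM, in an in vitro functional assay on HEK285-7 cells for antagonist activity at prostaglandin D2 receptor 2 (Homo sapiens), read by BRET and beta-arrestin recruitment; a lower number here means a stronger inhibitor, a higher number a weaker inhibitor.
Compound 2 `NS(=O)(=O)c1cccc(-c2nc(C(c3ccc(F)cc3)c3ccc(F)cc3)sc2CC(=O)O)c1` gives 710 nM in this assay.
Compound 3 `O=C(O)Cc1sc(C(c2ccc(F)cc2)c2ccc(F)cc2)nc1-c1ccco1` gives 140 nM in this assay.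

Compound 3 stands at the lowest number of the two that are known, with compound 2 as its nearest neighbour at a 5.1-fold lower number from compound 2 to compound 3 (0.71 log units; beyond the scatter). The unmeasured compound 4 `O=C(O)Cc1sc(C(c2ccc(F)cc2)c2ccc(F)cc2)nc1-c1ccnc(Cl)c1` differs from compound 3 by 2-chloropyridin-4-yl in place of furan-2-yl on an aromatic carbon. The measured steps that bear on this change are an at least 710-fold lower number from compound 1 to compound 3 (2.85 log units; beyond the scatter) and a 5.1-fold lower number from compound 2 to compound 3 (0.71 log units; beyond the scatter), both moving from a six-membered ring to the furan; the reverse direction, back to a six-membered ring, is therefore expected to raise the number modestly in this assay. For compound 4 an estimate of 450 nM is expected, within 120 nM to 2500 nM, which means an estimated step of a 3.2-fold higher number from compound 3 to compound 4 (0.51 log units; beyond the scatter).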

Compound 4, half-maximal inhibitory concentration: 39 nM
Estimate against measurement, compound 4: 12-fold (1.06 log units) above; measured number below the stated range.
By their numbers in this assay, from the lowest: compound 4; then compound 3; then compound 2. At a limit, above all of these: compound 1.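

At this position a six-membered aromatic ring carries no penalty in itself: 2-chloropyridin-4-yl in place of furan-2-yl gives a 3.6-fold lower number from compound 3 to compound 4 (0.56 log units; beyond the scatter), whereas both sulfamoylphenyl rings had stood higher than the furan. Among the six-membered rings, the outcome changes with the ring and its substituent, with an 18-fold lower number from compound 2 to compound 4 (1.26 log units; beyond the scatter). The widest step, an at least 2500-fold lower number from compound 1 to compound 4 (3.40 log units; beyond the scatter), rests on a limit and not on a number: the limit of > 100000 nM in this assay, at which 1 of the 4 values shown sits.

Going by these compounds, whether the chlorine or the ring nitrogen carries the gain stays open. A pyridin-4-yl without the chlorine, or a 3-chlorophenyl, at this position would separate the two.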